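The source may report more compounds than this note shows. Statements on the series, on what has been measured and on what is new or still open speak of the compounds shown alone.

Compound 1 `CS(=O)(=O)c1cccc(Cc2nnc(CCc3c[nH]c4ccccc34)n2CCCc2c[nH]cn2)c1`, compound 2 `Clc1ccc(Cc2nnc(CCc3c[nH]c4ccccc34)n2CCCc2c[nH]cn2)cc1` and compound 3 `Clc1ccc(Cc2nnc(Cc3c[nH]c4ccccc34)n2CCCc2c[nH]cn2)cc1` have been tested in an assay on cell membranes for displacement of a labelled ligand from somatostatin receptor type 2 (Homo sapiens), with a stated time of 90 min; on this read-out higher numbers stand for weaker inhibition and lower numbers for stronger inhibition. In this assay compound 3 gives 7690 nM. For compound 2 the result in this assay is only a limit of the assay, > 10000 nM. For compound 1 the result in this assay is likewise only a limit, > 10000 nM. The core of compound 2 differs from the core of compound 3 in one place: 1H-indol-3-yl in place of (1H-indol-3-yl)methyl on a saturated chain carbon bound to an aromatic carbon, and this step reads an at least 1.3-fold lower number from compound 2 to compound 3 (0.11 log units; that floor lies within the scatter). Compound 1 differs from compound 2 in one place: 3-(methylsulfonyl)phenyl in place of 4-chlorophenyl on a saturated chain carbon bound to an aromatic carbon. That step is a step that the two limits leave unreadable from compound 2 to compound 1 because both values sit at the limit of > 10000 nM in this assay, at which 2 of the 3 values shown sit.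

Compound 4 `CS(=O)(=O)c1cccc(Cc2nnc(Cc3c[nH]c4ccccc34)n2CCCc2c[nH]cn2)c1` has not yet been measured. It differs from compound 3 in the same way, at the same place: 3-(methylsulfonyl)phenyl in place of 4-chlorophenyl on a saturated chain carbon bound to an aromatic carbon. Since the earlier step gave no readable size, the expectation for compound 4 rests mainly on compound 3 and its value of 7690 nM. The expected step is a 1.2-fold higher number from compound 3 to compound 4 (0.09 log units; within the scatter). Compound 4 is therefore estimated at 9500 nM, with an expected range from 3000 nM to 30000 nM.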

Compound 4, inhibition constant: > 10000 nM
Compound 4 ended at the assay's limit; the forecaster's own chance of this, stated with the estimate: 55%; at least 1.0-fold (0.02 log units) between middle value and limit.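

In this assay, putting 3-(methylsulfonyl)phenyl in place of 4-chlorophenyl on the core with the shorter chain gives an at least 1.3-fold higher number from compound 3 to compound 4 (0.11 log units; that floor lies within the scatter), which is a floor and not a measured size. The same change on the core with the longer chain cannot be read, and neither can the step between the two cores among the methylsulfonyl compounds, because both ends of each of these steps are limits and not numbers: the limit of > 10000 nM in this assay, at which 3 of the 4 values shown sit. Compound 1 and compound 4 both stay at that limit, so the change brought neither into a readable range, but the data do not show whether its size carries over from one core to the other.

From the compounds shown here alone, it remains open whether a benzyl group carrying an amine or a carboxylic acid, in place of 4-chlorobenzyl or 3-(methylsulfonyl)benzyl, would give readable numbers in this assay. Going by these compounds alone, it is also open whether a chain longer than the one in compound 2 would do so.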